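Hydroxy added to the 4-methoxyphenyl group of compound 3

This account rests on a few compounds, and the source may have more. Where it says the series, first, only, none or still open, it means among the compounds named here.

In a functional assay on DU-145 cells (Homo sapiens) for cytotoxicity, read by trypan blue exclusion, with a stated time of 96 h (on this read-out lower numbers stand for stronger inhibition and higher numbers for weaker inhibition), compound 3 (`COc1ccc(NS(=O)(=O)/C=C/c2c(OC)cc(OC)cc2OC)cc1`) gives 200 nM. Compound 2 (`COc1ccc(NS(=O)(=O)/C=C/c2c(OC)cccc2OC)cc1`) gives 375 nM, and these two sit together at the low end of the numbers, within the scatter of each other. Compound 1 (`COc1cc(OC)c(/C=C/S(=O)(=O)Nc2ccc(F)c(N)c2)c(OC)c1`) stands far higher at 10000 nM.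

Compound 4 (`COc1cc(OC)c(/C=C/S(=O)(=O)Nc2ccc(OC)c(O)c2)c(OC)c1`) turns 4-methoxyphenyl into 3-hydroxy-4-methoxyphenyl: hydroxy in place of hydrogen on an aromatic carbon, ortho to a methoxy group and meta to a large group (hydroxy in place of hydrogen on an aromatic carbon).

Among the compounds with values here, two measured steps bear on this. The methoxy change, a 1.9-fold lower number from compound 2 to compound 3 (0.27 log units; within the scatter), lies elsewhere in the molecule and stays within the scatter. The change on the sulfonamide nitrogen, a 50-fold lower number from compound 1 to compound 3 (1.70 log units; beyond the scatter), concerns the group altered here and is large, so this group can move this assay strongly. Within the data shown here, no measured step isolates a hydroxy group, so the direction is only a tentative call.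

The expected outcome is a moderate move to a lower number, a 2.5-fold lower number from compound 3 to compound 4 (0.40 log units; beyond the scatter). For compound 4 the estimated value is 80 nM, with an expected range of 15 nM to 500 nM.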

Compound 4, half-maximal inhibitory concentration: 30 nM
Compound 4: middle estimate off by 2.7-fold (0.43 log units), on the high side; the range from low to high includes it.
By their numbers in this assay, from the lowest: compound 4; then compounds 3 and 2 (each within the scatter of the next); then compound 1.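

In this assay the hydroxy in place of hydrogen gives a 6.7-fold lower number from compound 3 to compound 4 (0.82 log units; beyond the scatter) on the 4-methoxyphenyl group, so one added heavy atom at this place moves the number beyond the scatter, while the methoxy change elsewhere in the molecule, a 1.9-fold lower number from compound 2 to compound 3 (0.27 log units; within the scatter), stays within it. Against 3-amino-4-fluorophenyl on the sulfonamide nitrogen, 3-hydroxy-4-methoxyphenyl gives a 330-fold lower number from compound 1 to compound 4 (2.52 log units; beyond the scatter), which is wider than a 50-fold lower number from compound 1 to compound 3 (1.70 log units; beyond the scatter) and makes this group the site of the largest span in the series so far. No measurement at hand explains what the hydroxy does here.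

On these data alone, it remains open whether a carboxylic acid or an ethoxy group at the place of the hydroxy would keep the number this low. As far as these compounds go, it is also open whether the same hydroxy would give a similar step on the core of compound 2.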